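Three Anilines Level in Cytotoxicity; a Propanoyl Newcomer

A few compounds are considered here, and "the series" means these few. Any claim that something is new, unique, unknown or untested is made for them only; others in the source may bear on it.

Compound 1 `c1ccc(-c2ccc(Cn3cncc3CNc3cccc(-c4ccccc4)c3)cc2)cc1`: 10000 nM
Compound 2 `Clc1ccc(Cn2cncc2CNc2cccc(-c3ccccc3)c2)cc1`: 10000 nM
Compound 3 `O=[N+]([O-])c1ccc(Cn2cncc2CNc2cccc(-c3ccccc3)c2)cc1`: 10000 nM

In a toxicity assay on NIH3T3 cells (Mus musculus) for cytotoxicity, read by resazurin assay (on this read-out higher numbers stand for an effect only at larger amounts of compound and lower numbers for an effect already at smaller amounts), compound 1 gives 10000 nM, and compounds 2 and 3 sit level with it at the digits shown. The three share one core and differ only in the group on the outer aromatic ring. Going from compound 1 to compound 2, no change at the digits printed from compound 1 to compound 2 (within the scatter), with chloro in place of phenyl on an aromatic carbon. Going from compound 1 to compound 3, no change at the digits printed from compound 1 to compound 3 (within the scatter), with nitro in place of phenyl. Going from compound 2 to compound 3, no change at the digits printed from compound 2 to compound 3 (within the scatter). None of these swaps moved the read-out beyond the scatter.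

Compound 4 `CCC(=O)c1ccc(NCc2cncn2Cc2ccc(-c3ccccc3)cc2)cc1-c1ccccc1` keeps the phenyl of compound 1 and carries a further change: propanoyl in place of hydrogen on an aromatic carbon

Within the data shown here, none of the measured steps touches this part of the core, so no step bears on it directly; the three that are known were all flat. The expectation is therefore that the step from compound 1 to compound 4 is no larger than the scatter, no change at the digits printed from compound 1 to compound 4 (within the scatter). Compound 4 is estimated at 10000 nM, within a range from 5000 nM to 20000 nM.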

Compound 4, half-maximal effective concentration: > 10000 nM
Compound 4 was reported as a limit; the forecaster's own chance of this, stated with the estimate: 40%; the middle value lies on the limit itself.
By their numbers in this assay, from the lowest: compounds 1, 2 and 3 (each within the scatter of the next).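

Compound 4 gives > 10000 nM in this assay, and this value is a limit of the assay, not a number. The three earlier swaps all lay on the outer aromatic ring, whereas compound 4 changes a different place, an aromatic carbon ortho to a phenyl group and para to a large group, and putting propanoyl in place of hydrogen there gives a number no lower from compound 1 to compound 4 (the limit leaves the size open), so this new place on the shared core has not yet yielded an effect at smaller amounts of compound. How large the step really is cannot be read, because of one thing: the limit of > 10000 nM in this assay, at which 1 of the 4 values shown sits.

The compounds shown do not tell whether an amine or a carboxylic acid on this same carbon would give a lower number than propanoyl does. Nor do they tell whether propanoyl would give the same kind of result with chloro or nitro on the outer ring, as in compound 2 and compound 3.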